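A few compounds are considered here, and "the series" means these few. Any claim that something is new, unique, unknown or untested is made for them only; others in the source may bear on it.

Three compounds share one core, differing only in the aromatic group attached to the carbonyl. Compound 1 `CC(C)Nc1sc(C(=O)c2cccc(C#N)c2)c(N)c1C#N` carries a nitrile-bearing benzene ring, compound 2 `CC(C)Nc1sc(C(=O)c2ccc(C#N)cc2)c(N)c1C#N` carries a differently substituted nitrile-bearing benzene ring, and compound 3 `CC(C)Nc1sc(C(=O)c2cccnc2)c(N)c1C#N` carries pyridin-3-yl. In an assay for inhibition of Maternal embryonic leucine zipper kinase (Homo sapiens), read by ADP-Glo, with a stated time of 0.5 h (a higher number here means a weaker inhibitor, a lower number a stronger inhibitor), compound 1 gives only a limit, > 5000 nM. In this assay compound 2 likewise gives only a limit, > 5000 nM. Compound 3 also reaches only a limit in this assay, > 5000 nM. Compound 3 therefore stands where all three measured compounds stand, at the limit of > 5000 nM in this assay, at which 3 of the 3 values shown sit, so no ranking among them is possible.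

Compound 4 `Cc1ccc(C(=O)c2sc(NC(C)C)c(C#N)c2N)s1` is the next variant: it has 5-methylthiophen-2-yl in place of pyridin-3-yl on a carbonyl carbon. Among the compounds with values here, no step between two measured compounds is available to set a scale for this change. Every aromatic group tried so far has left the value at the limit, so the expectation for compound 4 is a weak inhibitor again, with the step from compound 3 to compound 4 expected to be a step that the limit leaves unreadable from compound 3 to compound 4, that is, nothing clearly beyond the scatter. Compound 4 is estimated to give about 6000 nM in this assay, with a likely range from 1500 nM to 20000 nM.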

Compound 4, half-maximal inhibitory concentration: 494 nM
Estimate against measurement, compound 4: 12-fold (1.08 log units) above; measured number below the stated range.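

In this assay, the group on the carbonyl carbon turns out to matter: 5-methylthiophen-2-yl in place of pyridin-3-yl gives an at least 10-fold lower number from compound 3 to compound 4 (1.00 log units; beyond the scatter), so this position can carry a clear gain where the three earlier groups gave no readable value. The two groups have the same count of heavy atoms, hydrogen-bond donors and hydrogen-bond acceptors, and each is one aromatic ring with one hetero atom, so those counts do not separate them; what differs is a five-membered ring with sulfur and a methyl group against a six-membered ring with nitrogen. The true size of the step stays unknown because compound 3 has no exact number, and compound 4 is the only compound here that does: the limit of > 5000 nM in this assay, at which 3 of the 4 values shown sit.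

The compounds shown leave open whether the gain belongs to the sulfur-containing ring itself or to its methyl group, a question that plain thiophen-2-yl would help to settle. They also leave open how the number would respond to a longer chain such as ethyl, or to an amine, in place of that methyl group.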